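The source may report more compounds than this note shows. Statements on the series, on what has been measured and on what is new or still open speak of the compounds shown alone.

Compound 1 `COC(=O)C(=O)CNC1=CS(=O)(=O)O[C@@]12[C@@H](CO[Si](C)(C)C(C)(C)C)O[C@@H](n1cc(C)c(=O)n(C)c1=O)[C@@H]2O[Si](C)(C)C(C)(C)C`: 5570 nM
Compound 2 `Cc1cn([C@@H]2O[C@H](CO[Si](C)(C)C(C)(C)C)[C@@]3(OS(=O)(=O)C=C3NCC(=O)C(N)=O)[C@H]2O[Si](C)(C)C(C)(C)C)c(=O)n(C)c1=O`: 9960 nM
Compound 3 `Cc1cn([C@@H]2O[C@H](CO[Si](C)(C)C(C)(C)C)[C@@]3(OS(=O)(=O)C=C3NC(=O)NC(=O)c3ccccc3)[C@H]2O[Si](C)(C)C(C)(C)C)c(=O)n(C)c1=O`: 2290 nM

In a functional assay on CCRF-CEM cells (Homo sapiens) (a higher number here means that more compound is tolerated, a lower number that less compound is tolerated), compound 3 stands lowest of the three measured compounds, with compound 1 nearest and compound 2 furthest. Compound 4 `Cc1cn([C@@H]2O[C@H](CO[Si](C)(C)C(C)(C)C)[C@@]3(OS(=O)(=O)C=C3NCC(N)=O)[C@H]2O[Si](C)(C)C(C)(C)C)c(=O)n(C)c1=O` differs from compound 3 as follows: carbamoylmethyl in place of benzoylcarbamoyl on an amine nitrogen. The measured steps that bear on this change are a 2.4-fold lower number from compound 1 to compound 3 (0.39 log units; beyond the scatter) and a 4.3-fold lower number from compound 2 to compound 3 (0.64 log units; beyond the scatter); in both, the benzoylcarbamoyl compound carries the lower number against a compound bearing an amide-containing chain on the same nitrogen. Since compound 4 returns to such a chain, it is expected to give a higher number than compound 3, a step of about a 2.6-fold higher number from compound 3 to compound 4 (0.42 log units; beyond the scatter). For compound 4 the estimate is 6000 nM, with a range from 2500 nM to 14000 nM.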

Compound 4, half-maximal cytotoxic concentration: 14600 nM
For compound 4 the middle estimate is 2.4-fold (0.39 log units) below the measured one, outside the stated range (above it).
By their numbers in this assay, from the lowest: compound 3; then compounds 1, 2 and 4 (each within the scatter of the next, the first and the last beyond it).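

For the compounds shown here, replacing benzoylcarbamoyl on the amine nitrogen with carbamoylmethyl gives the largest step so far in this assay (a 6.4-fold higher number from compound 3 to compound 4 (0.80 log units; beyond the scatter)). The shorter chain stays level with the chain of compound 2 (a 1.5-fold higher number from compound 2 to compound 4 (0.17 log units; within the scatter)) but separates from the methoxycarbonyl-ended chain of compound 1 (a 2.6-fold higher number from compound 1 to compound 4 (0.42 log units; beyond the scatter)). Nothing given here explains these differences. Still open, on these data alone, is whether the benzoyl part or the carbamoyl link of benzoylcarbamoyl goes with the lower number, and how an amine or a carboxylic acid on this nitrogen's chain would read.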